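Para-substituent changes on the sulfonyl aryl ring

The source may hold more compounds than are shown below. What is called first, only, known or untested is meant among the compounds shown, and "the series" means these compounds.

Measured compounds:
- compound 1 `CCc1ccc(S(=O)(=O)N2CCC(N3CCC(C)CC3)CC2)cc1`: > 5000 nM
- compound 2 `COc1ccccc1-c1ccc(S(=O)(=O)N2CCC(N3CCC(C)CC3)CC2)cc1`: 26 nM
- compound 3 `CC1CCN(C2CCN(S(=O)(=O)c3ccc(OCc4ccccc4)cc3)CC2)CC1`: 385 nM

In a functional assay on DLD-1 cells (Homo sapiens) for antiproliferative activity, read by CellTiter-Glo, with a stated time of 72 h (on this read-out higher numbers stand for weaker inhibition and lower numbers for stronger inhibition), compound 1 gives only a limit, > 5000 nM, not a number. Compound 2 gives 26 nM and compound 3 gives 385 nM; of the two numbers compound 3 is the higher, with a 15-fold higher number from compound 2 to compound 3 (1.17 log units; beyond the scatter). The shared core is kept throughout; the two measured steps from compound 1 each exchange ethyl for a larger group: an at least 190-fold lower number from compound 1 to compound 2 (2.28 log units; beyond the scatter) and an at least 12-fold lower number from compound 1 to compound 3 (1.11 log units; beyond the scatter).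

Compound 4 `CC1CCN(C2CCN(S(=O)(=O)c3ccc(C(C)C)cc3)CC2)CC1` is not yet measured. It differs from compound 3 by isopropyl in place of benzyloxy on an aromatic carbon. Among the compounds with values here, the step that bears on this is the one from compound 1 to compound 3, which runs the opposite way: an at least 12-fold lower number from compound 1 to compound 3 (1.11 log units; beyond the scatter). Isopropyl is a small alkyl group like ethyl, so a large rise in the number is expected for compound 4, a 10-fold higher number from compound 3 to compound 4 (1.02 log units; beyond the scatter), back toward the limit at which compound 1 sits. Compound 4 is therefore estimated at 4000 nM, between 1000 nM and 15000 nM.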

Compound 4, half-maximal inhibitory concentration: 685 nM
Estimate against measurement, compound 4: 5.8-fold (0.77 log units) above; measured number below the stated range.
By their numbers in this assay, from the lowest: compound 2; then compounds 3 and 4 (each within the scatter of the next). At a limit, above all of these: compound 1.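

In this assay, isopropyl and benzyloxy at this position cannot be told apart, with a 1.8-fold higher number from compound 3 to compound 4 (0.25 log units; within the scatter), so neither the aromatic ring nor the oxygen of benzyloxy is required for this level of activity. Methyl in place of hydrogen on the ethyl chain already gives an at least 7.2-fold lower number from compound 1 to compound 4 (0.86 log units; beyond the scatter), and this step has no fixed size, as compound 1 gives a limit and not a number: the limit of > 5000 nM in this assay, at which 1 of the 4 values shown sits. The 2-methoxyphenyl group of compound 2 remains clearly apart, with a 26-fold higher number from compound 2 to compound 4 (1.42 log units; beyond the scatter).

On these data alone, it remains open whether the gain with 2-methoxyphenyl depends on its methoxy group, which unsubstituted phenyl would test. As far as these compounds go, it is equally open how a tert-butyl group, a cyclopropyl group, an amine or a carboxylic acid would behave at this position.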